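Replacing an amide with a urea on a pyrazole scaffold

The source may report more compounds than this note shows. Statements on the series, on what has been measured and on what is new or still open speak of the compounds shown alone.

The study examines three compounds sharing one core. Compound 1 `COc1cc(-c2nn(-c3cccc(NC(=O)c4ccc(Cl)c(C(F)(F)F)c4)c3)cc2-c2ccncc2)ccc1Cl` carries a 4-chloro-3-(trifluoromethyl)phenyl on the carbonyl carbon. In a functional assay on HCT-116 cells (Homo sapiens) for inhibition, read by sulforhodamine B assay, with a stated time of 48 h (a higher number here means a weaker inhibitor of growth, a lower number a stronger inhibitor of growth), compound 1 gives only a limit of the assay, > 32500 nM, so its standing on the numbers is known just from that limit (the limit of > 32500 nM in this assay, at which 1 of the 2 values shown sits). Among the measured compounds shown here, compound 2 `O=C(Nc1cccc(-n2cc(-c3ccncc3)c(-c3ccc(Cl)c(O)c3)n2)c1)Nc1cc(C(F)(F)F)cc(C(F)(F)F)c1` differs in more than one place and is the only measured compound with a number; in this assay compound 2 gives 1110 nM.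

Compound 3 `COc1cc(-c2nn(-c3cccc(NC(=O)Nc4cccc(C(F)(F)F)c4)c3)cc2-c2ccncc2)ccc1Cl` is not yet measured. It differs from compound 1 by (3-(trifluoromethyl)phenyl)amino in place of 4-chloro-3-(trifluoromethyl)phenyl on a carbonyl carbon.

For the measured compounds named here, no measured pair differing in one place is available, so the size of this step rests on what compound 2 shows. The author expects the step from compound 1 to compound 3 to be a gain beyond the scatter, an at least 5.4-fold lower number from compound 1 to compound 3 (0.73 log units; beyond the scatter), though a limit remains possible. For compound 3 the estimate in this assay is 6000 nM, with a range from 1200 nM to 32500 nM.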

Compound 3, concentration for total growth inhibition: 7170 nM
Compound 3: the middle estimate sits 1.2-fold (0.08 log units) below what was measured, and the stated range covers the measured number.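

Among the compounds shown here, on the carbonyl carbon, putting (3-(trifluoromethyl)phenyl)amino in place of 4-chloro-3-(trifluoromethyl)phenyl gives, in this assay, an at least 4.5-fold lower number from compound 1 to compound 3 (0.65 log units; beyond the scatter), which is the only reading of a single change at this place. Going by these compounds, the true size of the step remains unknown, since the value for compound 1 is a limit and not a number: the limit of > 32500 nM in this assay, at which 1 of the 3 values shown sits. The change turns the amide into a urea and also removes the chlorine, so this one step credits the gain to the whole swap and to neither part alone.

On these data alone, what remains open is which part carries the gain, a question that (4-chloro-3-(trifluoromethyl)phenyl)amino on the same carbonyl carbon would address. As far as these compounds go, whether the aryl ring is needed at all also stays open, and a simple amine such as cyclohexylamino at this place would bear on that.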